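The source may hold more compounds than are shown below. What is called first, only, known or untested is meant among the compounds shown, and "the series" means these compounds.

Measured compounds, with their read-outs in a functional assay on K562 cells (Homo sapiens) for cytotoxicity, read by sulforhodamine B assay, with a stated time of 48 h, tested at 0.1 uM; a higher number here means a weaker effect of the compound at the concentration tested, a lower number a stronger effect:
compound 1 `COc1cc(-c2cc(/C=C/C(=O)c3ccc(N)cc3)[nH]n2)cc(OC)c1OC`: 94%
compound 2 `COc1ccc(C(=O)/C=C/c2cc(-c3cc(OC)c(OC)c(OC)c3)n[nH]2)cc1OC`: 92%

Compound 2 holds the lower of the two numbers, but the step of a number 2 percentage points lower from compound 1 to compound 2 (within the scatter) lies within the scatter, so the two compounds cannot be told apart on these data; both leave most of the cells growing at the concentration tested. The next compound, compound 3 `COc1cc(C(=O)/C=C/c2cc(-c3cc(OC)c(OC)c(OC)c3)n[nH]2)cc(OC)c1OC`, has not yet been measured. It differs from compound 2 by methoxy in place of hydrogen on an aromatic carbon. Going by the values given here, no measured step bears on a change of this kind: the only step on record, 3,4-dimethoxyphenyl in place of 4-aminophenyl on a carbonyl carbon, is a different kind of change and itself stays within the scatter. With nothing to lean on and both measured values near the top of the scale, a step of a number 1 percentage points lower from compound 2 to compound 3 (within the scatter) in this assay is expected, that is, none beyond the scatter. Compound 3 is therefore estimated at 91%, within a range from 76% to 103%.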

Compound 3, a percentage reported as activity, at one concentration (the size of the read-out at that concentration, not a potency): 104%
For compound 3 the middle estimate is 13 percentage points below the measured one; measured number outside the range, above it.
By their numbers in this assay, from the lowest: compounds 2, 1 and 3 (each within the scatter of the next, the first and the last beyond it).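

In this assay, methoxy in place of hydrogen on an aromatic carbon, ortho to a methoxy group and meta to a large group, gives a number 12 percentage points higher from compound 2 to compound 3 (beyond the scatter). Going by these compounds alone, this is the first step that rises above the scatter, so this position on the ring attached to the carbonyl does respond to a change, though modestly, and here the added methoxy moves the number towards a weaker effect at the concentration tested. The data give no measured property or other finding that explains this shift.

The compounds shown leave open whether the response is specific to methoxy, since a smaller or different substituent at the same position, such as a hydroxyl group or a chlorine atom, would show whether any replacement of this hydrogen weakens the effect or only this one does. Each compound is also represented by a single read-out at one concentration, so the step describes the size of the effect at that concentration and says nothing about the effect at any other concentration.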